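Acetylation of the pyrrolidine amine in the shared core

The compounds below may be only part of what the source reports. "The series", "measured", "known", "first", "only" and "open" are said of these compounds alone.

Measured compounds:
- compound 1 `NC1CCN(c2nc3c(c(Nc4ccc(C(F)(F)F)cc4)n2)CCN(c2ncccc2C(F)(F)F)CC3)C1` gives 3700 nM in a functional assay on HEK293 cells for antagonist activity at transient receptor potential cation channel subfamily V member 1 (Homo sapiens), read by FLIPR and calcium flux; a higher number here means a weaker inhibitor, a lower number a stronger inhibitor
- compound 2 `FC(F)(F)c1ccc(Nc2nc(N3CCN(C4CCC4)CC3)nc3c2CCN(c2ncccc2C(F)(F)F)CC3)cc1` gives 24 nM in this assay
- compound 3 `CNC1CCN(c2nc3c(c(Nc4ccc(C(F)(F)F)cc4)n2)CCN(c2ncccc2C(F)(F)F)CC3)C1` gives 2790 nM in this assay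

Compound 1 stands at the highest of the three numbers. Its nearest neighbour is compound 3, reached by a 1.3-fold lower number from compound 1 to compound 3 (0.12 log units; within the scatter), a step within the scatter. The furthest is compound 2, reached by a 150-fold lower number from compound 1 to compound 2 (2.19 log units; beyond the scatter); the reverse direction, a 120-fold higher number from compound 2 to compound 3 (2.07 log units; beyond the scatter), is of the same order. Both large steps exchange the whole ring attached to the aromatic carbon, not a substituent on the amine nitrogen.

Compound 4 `CC(=O)NC1CCN(c2nc3c(c(Nc4ccc(C(F)(F)F)cc4)n2)CCN(c2ncccc2C(F)(F)F)CC3)C1` is not yet measured. It differs from compound 1 as follows: acetyl in place of hydrogen on an amine nitrogen. For the measured compounds named here, the only measured step that touches the same nitrogen is the one from compound 1 to compound 3, and it was within the scatter. Going by the values given here, no measured step adds a carbonyl-bearing group to this nitrogen, so the bearing of the acetyl is less certain than that of a methyl. On this basis a small step at most is expected, and in this assay compound 4 is estimated at 4200 nM (range 1500 nM to 12000 nM), which would mean a 1.1-fold higher number from compound 1 to compound 4 (0.06 log units; within the scatter), a change expected to stay within the scatter.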

Compound 4, half-maximal inhibitory concentration: 150 nM
Compound 4: middle estimate off by 28-fold (1.45 log units), on the high side; the whole stated range lies above it.
By their numbers in this assay, from the lowest: compound 2; then compound 4; then compounds 3 and 1 (each within the scatter of the next).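

At the amine nitrogen on the saturated ring carbon, the substituent does change the result in this assay: acetyl in place of hydrogen gives a 25-fold lower number from compound 1 to compound 4 (1.39 log units; beyond the scatter) and acetyl in place of methyl gives a 19-fold lower number from compound 3 to compound 4 (1.27 log units; beyond the scatter) while methyl in place of hydrogen stayed within the scatter. The earlier flat reading of this nitrogen therefore holds for methyl only and does not extend to acetyl, so the pair of compound 1 and compound 3 was a poor guide to the position. The 3-acetamidopyrrolidin-1-yl group closes much of the earlier gap to 4-cyclobutylpiperazin-1-yl but not all of it, with a 6.3-fold higher number from compound 2 to compound 4 (0.80 log units; beyond the scatter) still beyond the scatter, and nothing on hand accounts for the difference between acetyl and methyl on this nitrogen.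

From the compounds shown here alone, it stays open whether the effect belongs to the acetyl alone or to carbonyl-bearing groups more widely, which a propanoyl group, a longer acyl chain or a urea on the same nitrogen would test. A methanesulfonyl group would show whether the carbonyl is needed at all, and an acetamido group on a piperidine ring would show whether the result carries beyond the pyrrolidine.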